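The source may hold more compounds than are shown below. What is called first, only, known or untested is meant among the compounds shown, and "the series" means these compounds.

In a functional assay on A-375 cells (Homo sapiens) for inhibition, read by CCK-8 assay, with a stated time of 72 h, tested at 2 uM (a higher number here means more inhibition of growth at the concentration tested, a lower number less inhibition of growth), the series so far reads:
- compound 1 `Nc1ccccc1NC(=O)/C=C/c1ccc(CSc2ccc(Cl)cc2)cc1` gives 13.4%
- compound 2 `Nc1ccccc1NC(=O)/C=C/c1ccc(CSc2ccc(F)cc2)cc1` gives 28.8%

For the measured compounds named here, of these two, compound 2 stands higher, at 28.8%, and compound 1 is its only neighbour. The next compound is compound 3 `Nc1ccccc1NC(=O)/C=C/c1ccc(CSc2cccc3ccccc23)cc1`, with the change naphthalen-1-yl in place of 4-fluorophenyl on a sulfur.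

Going by the values given here, only one measured step bears on this, a number 15.4 percentage points higher from compound 1 to compound 2 (beyond the scatter), a modest move beyond the scatter, with fluoro in place of chloro on an aromatic carbon. It touches the same group on the sulfur, but only through a single substituent, so it is indirect evidence. It does show that the read-out responds to changes at this end of the molecule, and that the one departure from the 4-fluorophenyl group seen so far, in compound 1 at 13.4%, gave a lower number. Among the compounds with values here, no measured compound carries a naphthalen-1-yl group, so the range stays wide. A modest fall is expected, of about the size of the measured step or somewhat smaller.

The expected change is a number 11.8 percentage points lower from compound 2 to compound 3 (beyond the scatter). For compound 3 the estimated value is 17%, with an expected range of 3% to 33%.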

Compound 3, percent growth inhibition at one concentration: 1.55%
For compound 3 the middle estimate is 15.5 percentage points above the measured one; measured number below the stated range.
By their numbers in this assay, from the lowest: compound 3; then compound 1; then compound 2.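

In this assay, for the compounds shown here, the change of the whole aromatic group on the sulfur gives a number 27.3 percentage points lower from compound 2 to compound 3 (beyond the scatter) and is the largest step so far, and the same change read against the chloro analogue gives a number 11.9 percentage points lower from compound 1 to compound 3 (beyond the scatter) in the same direction. The earlier pair showed only that exchanging one substituent on a single six-membered aromatic ring moves the number, whereas this result shows that going to naphthalen-1-yl, with two such rings, leaves compound 3 at 1.55% and lowest of the three, with both of its steps beyond the scatter, so that growth inhibition at the tested concentration is nearly gone. Nothing at hand gives a reason for this order among the three compounds.

The compounds shown leave open whether the loss belongs to the second ring as such or to the way it is attached, a question that naphthalen-2-yl or an unsubstituted phenyl on the sulfur would address. Also open, as far as these compounds go, is how a saturated cyclohexyl group, or a 4-phenyl ring carrying an amine or a carboxylic acid, would read at this position.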